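Swapping a Difluorophenyl for Bromophenyl on the Carbonyl

A few compounds are considered here, and "the series" means these few. Any claim that something is new, unique, unknown or untested is made for them only; others in the source may bear on it.

Compound 1 `COc1cc(-c2nnc3n2NC(c2cccs2)C(C(=O)c2ccccc2)S3)cc(OC)c1OC` reaches only a limit in a functional assay on MCF7 cells (Homo sapiens) for cytotoxicity, read by MTT assay, with a stated time of 48 h (a lower number here means a stronger inhibitor, a higher number a weaker inhibitor), reported as > 100000 nM. For the measured compounds named here, compound 2 `COc1cc(-c2nnc3n2NC(c2ccco2)C(C(=O)c2ccc(F)c(F)c2)S3)cc(OC)c1OC` is the one compound with a number: in this assay compound 2 gives 73200 nM, placing it as the sole measured value. The other entry, that of compound 1, is a limit (the limit of > 100000 nM in this assay, at which 1 of the 2 values shown sits). Compound 3 `COc1cc(-c2nnc3n2NC(c2ccco2)C(C(=O)c2cccc(Br)c2)S3)cc(OC)c1OC` differs from compound 2 by 3-bromophenyl in place of 3,4-difluorophenyl on a carbonyl carbon. Going by the values given here, no measured step is available to guide this change, so I expect little movement beyond the scatter. I estimate compound 3 at 70000 nM, between 25000 nM and 150000 nM, a step of a 1.0-fold lower number from compound 2 to compound 3 (0.02 log units; within the scatter).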

Compound 3, half-maximal inhibitory concentration: 91800 nM
For compound 3 the middle estimate is 1.3-fold (0.12 log units) below the measured one, within the range that was stated.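

In this assay, 3-bromophenyl in place of 3,4-difluorophenyl on the carbonyl carbon gives a 1.3-fold higher number from compound 2 to compound 3 (0.10 log units; within the scatter), so this swap produces no readable change at this position. This is the only measured step shown, and it compares just two halogen-bearing phenyl groups. No measurement shown explains why these two groups read alike. Still open, as far as these compounds go, is how this position would respond to a phenyl ring carrying an amine or a carboxylic acid, or to a longer chain in place of the ring.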